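A few compounds are considered here, and "the series" means these few. Any claim that something is new, unique, unknown or untested is made for them only; others in the source may bear on it.

Measured so far in an ADME assay on MT4 cells (Homo sapiens) for cytotoxicity, read by MTT assay; on this read-out lower numbers stand for higher toxicity in this test and higher numbers for lower toxicity in this test:
- compound 1 `COc1ccc(NC(=S)OCCc2ccccc2)cc1`: 36000 nM
- compound 2 `S=C(Nc1ccc(Cl)cc1)OCCc1ccncc1`: 70000 nM
- compound 3 `O=[N+]([O-])c1ccc(NC(=S)OCCc2ccncc2)cc1`: > 100000 nM

Compound 3 stands at the edge of what this assay can report. For compound 3 the value > 100000 nM is a limit of the assay, not a measured number (the limit of > 100000 nM in this assay, at which 1 of the 3 values shown sits). Going by the values given here, the one step that touches this region runs an at least 1.4-fold higher number from compound 2 to compound 3 (0.15 log units; that floor lies within the scatter), and it ends at that limit, so its true size is unknown.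

Compound 4 `COc1ccc(NC(=S)OCCc2ccncc2)cc1` differs from compound 3 in one place: methoxy in place of nitro on an aromatic carbon. Among the compounds with values here, no measured step swaps methoxy for nitro directly. Within the data shown here, the only comparison that touches the same position is the one from compound 2 to compound 3, and it left the number at the floor of the assay. Among the other numbers, compound 1 carries a methoxy group on a different core and gives 36000 nM, while on the same core as compound 4, compound 2 gives 70000 nM.

With so little to lean on, compound 4 is expected to land near the top of the measured range, with a step of an at least 1.4-fold lower number from compound 3 to compound 4 (0.15 log units; that floor lies within the scatter). The estimate for compound 4 is 70000 nM, within a range from 35000 nM to 150000 nM.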

Compound 4, half-maximal cytotoxic concentration: 59000 nM
For compound 4 the middle estimate is 1.2-fold (0.07 log units) above the measured one; the range from low to high includes it.
By their numbers in this assay, from the lowest: compounds 1, 4 and 2 (each within the scatter of the next). At a limit, above all of these: compound 3.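

In this assay the value of compound 3, > 100000 nM, is a limit and not a number. Methoxy in place of nitro on this aromatic carbon gives an at least 1.6-fold lower number from compound 3 to compound 4 (0.22 log units; that floor lies within the scatter), so even this swap shows no change beyond the scatter, and the true size of the step stays unknown because it starts at a limit: the limit of > 100000 nM in this assay, at which 1 of the 4 values shown sits. On the shared core, methoxy and chloro at this place cannot be told apart, with a 1.2-fold lower number from compound 2 to compound 4 (0.07 log units; within the scatter), and pyridin-4-yl in place of phenyl also stays within the scatter, with a 1.6-fold higher number from compound 1 to compound 4 (0.21 log units; within the scatter).

So methoxy, chloro and the swap of phenyl for pyridin-4-yl leave the number where it was, while how far nitro truly stands from methoxy and chloro remains unresolved. On these data alone, it also remains open whether an amine or a carboxylic acid on this aromatic carbon, or a longer chain leading to the pyridin-4-yl group, would move the number clearly beyond the scatter.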